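Flavone ester series: methyl placement on the aryl ester

This account rests on a few compounds, and the source may have more. Where it says the series, first, only, none or still open, it means among the compounds named here.

Working notes. Compound 1 `C=C(CCc1cc(O)c2c(=O)cc(-c3ccccc3)oc2c1)Cc1c(Br)cccc1C(=O)CC` and compound 2 `COC(=O)c1ccc(C)cc1OC(=O)COc1cc(O)c2c(=O)cc(-c3ccccc3)oc2c1` share the same core. In a functional assay on cells (T-cell, Mus musculus, strain BALB/c) for inhibition, read by MTT assay, with a stated time of 72 h (a higher number here means a weaker inhibitor, a lower number a stronger inhibitor), compound 1 gives 40700 nM, and compound 2 gives 31100 nM, the lower of the two numbers, though the gap to compound 1 falls within the scatter, so no order can be read from it. Compound 3 `COC(=O)c1cccc(C)c1OC(=O)COc1cc(O)c2c(=O)cc(-c3ccccc3)oc2c1` keeps the same atoms as compound 2, joined differently: a group of 11 heavy atoms (9 carbon, 2 oxygen; one six-membered aromatic ring of carbon only) in place of a group of 11 heavy atoms (9 carbon, 2 oxygen; one six-membered aromatic ring of carbon only), on an oxygen next to a carbonyl group. Among the measured compounds shown here, no step between measured compounds exists to guide this, so no change beyond the scatter is expected; the estimated step of a 1.0-fold lower number from compound 2 to compound 3 (0.00 log units; within the scatter) reflects that. Compound 3 is estimated at 31000 nM in this assay, with a range from 12000 nM to 80000 nM.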

Compound 3, half-maximal inhibitory concentration: 39100 nM
Compound 3: the middle estimate sits 1.3-fold (0.10 log units) below what was measured, and the stated range covers the measured number.
By their numbers in this assay, from the lowest: compounds 2, 3 and 1 (each within the scatter of the next).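

In this assay, the step at this place, on an oxygen next to a carbonyl group, is a 1.3-fold higher number from compound 2 to compound 3 (0.10 log units; within the scatter). Rearranging the same atoms within the aryl ester group therefore gives two compounds that this read-out does not separate, which is the first direct comparison at this position. Nothing at hand bears on the reason for this result. Still open, on these data alone, is whether a carboxylic acid in place of the methyl ester, or an amine on the aromatic ring, would give a step beyond the scatter.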